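Swapping chloro for methoxymethyl on a phenyl ring

The source may report more compounds than this note shows. Statements on the series, on what has been measured and on what is new or still open speak of the compounds shown alone.

Of the compounds shown here, three built on one shared core have been tested in a functional assay on CHO cells for agonist activity at Alpha-1A adrenergic receptor (Homo sapiens), read by FLIPR and calcium flux; on this read-out higher numbers stand for larger maximal responses and lower numbers for smaller maximal responses. Compound 1, `c1ccc(C2Cc3nccn3C2)cc1`, carries an unsubstituted phenyl ring and gives 80%; 74%; 25%; 85% (4 entries) in this assay; the spread of these entries, (the several entries of compound 1 in this assay, 80%; 74%; 25%; 85% (4 entries)), shows how far repeats of this kind can wander. Compound 3, `c1ccc(C2CCc3nc[nH]c3C2)cc1`, has a larger core with a hydrogen on one ring nitrogen and gives 78%; 75%; 76% (3 entries), with its repeats, (the several entries of compound 3 in this assay, 78%; 75%; 76% (3 entries)), sitting close together. Among the compounds with values here, compound 2, `Clc1ccccc1C1Cc2nccn2C1`, places a chloro on the phenyl ring and gives 56%; this is the single number available for compound 2, as two further entries report no number at all.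

Compound 4, `COCc1ccccc1C1Cc2nccn2C1`, differs from compound 2 in one place: methoxymethyl in place of chloro on an aromatic carbon. Within the data shown here, no pair of measured compounds shows this exchange, so nothing in the data says which way the maximal response should move. From compound 2 to compound 4 the expected step is a number 4 percentage points higher from compound 2 to compound 4 (within the scatter), which is within the scatter rather than a real change in either direction. For compound 4 the expected maximal response is therefore 60%, with a range from 30% to 90%.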

Compound 4, largest response reached (Emax), in percent of the reference or control that the assay uses: 77%
Compound 4: the middle estimate sits 17 percentage points below what was measured, within the range that was stated.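

Methoxymethyl in place of chloro on this aromatic carbon gives a number 21 percentage points higher from compound 2 to compound 4 (beyond the scatter) in this assay, the first reading of this exchange among the compounds shown. The position, ortho to a group of 8 heavy atoms, therefore accepts methoxymethyl, with 3 heavy atoms and 1 hydrogen-bond acceptor, in place of chloro, with 1 heavy atom, and the maximal response does not fall. The step rests on the single number for compound 2, so it calls for some care, as repeats of one compound in this assay can lie far apart: the several entries of compound 1 in this assay, 80%; 74%; 25%; 85% (4 entries)

The compounds shown leave open whether the higher response goes with the oxygen of methoxymethyl or with the greater length of the group, a question that a plain propyl chain at the same place would help to answer. Also open, as far as these compounds go, are how an aminomethyl group or a carboxylic acid would behave on this aromatic carbon, and whether the same exchange would give a similar step on the core of compound 3.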